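This account rests on a few compounds, and the source may have more. Where it says the series, first, only, none or still open, it means among the compounds named here.

Measured in an ADME assay on microsomes from liver (Mus musculus) for metabolic stability; on this read-out higher numbers stand for fast clearance and lower numbers for slow clearance:
Compound 1 `CN1C(=O)C2=C(C1=O)N(CC(=O)Nc1ccc(-c3ccccc3)cc1)CCC2`: 25 mL.min-1.g-1
Compound 2 `CN1C(=O)C2=C(C1=O)N(CC(=O)Nc1ccc(-c3nccs3)cc1)CCC2`: 65 mL.min-1.g-1
Compound 3 `CN1C(=O)C2=C(C1=O)N(CC(=O)Nc1ccc(-c3cccnc3)cc1)CCC2`: 48 mL.min-1.g-1

Compound 3 cannot be told apart from either of the other two, the steps being a 1.9-fold higher number from compound 1 to compound 3 (0.28 log units; within the scatter) and a 1.4-fold lower number from compound 2 to compound 3 (0.13 log units; within the scatter). Compound 4 `CN1C(=O)C2=C(C1=O)N(CC(=O)Nc1ccc(-c3ccccn3)cc1)CCC2` carries pyridin-2-yl in place of pyridin-3-yl on an aromatic carbon, para to a large group: pyridin-2-yl in place of pyridin-3-yl on an aromatic carbon. Among the measured compounds shown here, no measured step makes this exact exchange. The closest ones replace one ring with another at the same place, and the largest of them, a 2.6-fold higher number from compound 1 to compound 2 (0.41 log units; beyond the scatter), is modest. Accordingly, no change beyond the scatter is expected, and the estimated step is a 1.0-fold higher number from compound 3 to compound 4 (0.02 log units; within the scatter). In this assay, compound 4 is expected at 50 mL.min-1.g-1, with an estimated range of 25 mL.min-1.g-1 to 100 mL.min-1.g-1.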

Compound 4, intrinsic clearance in microsomes: 38 mL.min-1.g-1
For compound 4 the middle estimate is 1.3-fold (0.12 log units) above the measured one, and the stated range covers the measured number.
By their numbers in this assay, from the lowest: compounds 1, 4, 3 and 2 (each within the scatter of the next, the first and the last beyond it).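

In this assay, the step for the change of attachment within the pyridine, a 1.3-fold lower number from compound 3 to compound 4 (0.10 log units; within the scatter), shows that pyridin-2-yl and pyridin-3-yl cannot be told apart at this place, para to a large group. Pyridin-2-yl also cannot be told apart from the other two rings, with a 1.7-fold lower number from compound 2 to compound 4 (0.23 log units; within the scatter) and a 1.5-fold higher number from compound 1 to compound 4 (0.18 log units; within the scatter). No evidence is available that bears on this result.

As far as these compounds go, whether pyridin-4-yl, a saturated morpholine ring or a carboxylic acid at this place would give a step beyond the scatter remains open. So does the effect of an amine on the outer ring.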